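Chloro in Place of Methoxy on the Benzyl Ring

The source may hold more compounds than are shown below. What is called first, only, known or untested is meant among the compounds shown, and "the series" means these compounds.

Compound 1 `O=S(=O)(NCCCNCc1cccc2ccccc12)c1cc(C(F)(F)F)cc(C(F)(F)F)c1` gives 1400 nM in a functional assay on MCF7 cells (Homo sapiens) for inhibition, read by MTT assay, with a stated time of 72 h; a higher number here means a weaker inhibitor of growth, a lower number a stronger inhibitor of growth.
Compound 2 `COc1ccc(CNCCCNS(=O)(=O)c2cc(C(F)(F)F)cc(C(F)(F)F)c2)cc1OC` gives 1900 nM in this assay.
Compound 3 `COc1cccc(CNCCCNS(=O)(=O)c2cc(C(F)(F)F)cc(C(F)(F)F)c2)c1` gives 2400 nM in this assay.

Compound 3 has the highest of the three numbers, but its nearest neighbour is compound 2 at a 1.3-fold higher number from compound 2 to compound 3 (0.10 log units; within the scatter) and its furthest is compound 1 at a 1.7-fold higher number from compound 1 to compound 3 (0.23 log units; within the scatter), so all three compounds sit within the scatter of one another and none can be called the stronger or weaker inhibitor of growth.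

Compound 4 `O=S(=O)(NCCCNCc1cccc(Cl)c1)c1cc(C(F)(F)F)cc(C(F)(F)F)c1` differs from compound 3 in one place: chloro in place of methoxy on an aromatic carbon. The step that bears most directly on this is the one where hydrogen replaces the same methoxy, a 1.3-fold higher number from compound 2 to compound 3 (0.10 log units; within the scatter), which stayed within the scatter. The two steps that exchange the whole aromatic group, a 1.4-fold higher number from compound 1 to compound 2 (0.13 log units; within the scatter) and a 1.7-fold higher number from compound 1 to compound 3 (0.23 log units; within the scatter), likewise stayed within the scatter. On this evidence the shared core tolerates a range of groups on the benzyl ring without a measurable shift, and no step beyond the scatter is expected for compound 4 in this assay.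

Compound 4 is therefore estimated at 2200 nM, with a range of 1000 nM to 5000 nM. The expected step from compound 3 is a 1.1-fold lower number from compound 3 to compound 4 (0.04 log units; within the scatter).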

Compound 4, concentration for 50% growth inhibition: 2600 nM
Compound 4: middle estimate off by 1.2-fold (0.07 log units), on the low side, within the range that was stated.
By their numbers in this assay, from the lowest: compounds 1, 2, 3 and 4 (each within the scatter of the next).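

At the aromatic carbon that carries the methoxy of compound 3, chloro takes the place of that group in this assay (a 1.1-fold higher number from compound 3 to compound 4 (0.03 log units; within the scatter)), which is the first change shown at this carbon, since the earlier hydrogen-for-methoxy step removed the other methoxy of compound 2 and left this one in place. A group of one heavy atom and no hydrogen-bond acceptor thus replaces one of two heavy atoms and one hydrogen-bond acceptor without a measurable shift, and the wider exchanges of the aromatic group (a 1.4-fold higher number from compound 2 to compound 4 (0.14 log units; within the scatter); a 1.9-fold higher number from compound 1 to compound 4 (0.27 log units; within the scatter)) also stay within the scatter, so the four compounds form a single group with none going against this pattern. Nothing measured here on these groups offers an account of why the change leaves the number in place.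

As far as these compounds go, whether a carboxylic acid or an amine on this aromatic carbon, or a longer chain in the shared core, would move the number beyond the scatter stays open. Also open, from the compounds shown here alone, is whether a chloro at another carbon of the benzyl ring would behave as this one does.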